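The source may report more compounds than this note shows. Statements on the series, on what has been measured and on what is new or still open speak of the compounds shown alone.

Measured so far in a functional assay on HT-29 cells (Homo sapiens) for antiproliferative activity, read by MTT assay, with a stated time of 24 h, tested at 10 uM; on this read-out lower numbers stand for less inhibition and higher numbers for more inhibition at the one concentration tested (going by the name of the read-out):

compound 1 `Cc1ccc(S(=O)(=O)NC(=O)n2ccc3cccnc32)cc1`: 33.4%
compound 2 `O=C(NS(=O)(=O)c1ccc2ccccc2c1)n1ccc2cccnc21`: 16.2%
compound 3 `O=C(NS(=O)(=O)c1ccc2ccccc2c1)n1ccc2cc(Br)cnc21`: 60.1%

Compound 2 stands lowest of the three numbers in this assay; compound 1 lies above it beyond the scatter, compound 3 further above. Compound 4 `O=C(NS(=O)(=O)c1ccc2ccccc2c1)n1ccc2c(Cl)ccnc21` differs from compound 2 by chloro in place of hydrogen on an aromatic carbon. Within the data shown here, the one measured step that bears on this is a number 43.9 percentage points higher from compound 2 to compound 3 (beyond the scatter), which also brings a halogen onto the shared core. Among the measured compounds shown here, that step is the only guide, and it concerns a different halogen at a different spot of the core, so its size is not expected to carry over fully; a rise beyond the scatter is expected, of smaller size. Compound 4 is therefore estimated at 40%, range 18% to 62%, an expected step of a number 23.8 percentage points higher from compound 2 to compound 4 (beyond the scatter).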

Compound 4, a percentage reported as inhibition, at one concentration (the size of the read-out at that concentration, not a potency): 58.2%
The estimate for compound 4 lay 18.2 percentage points below the measured number; the range from low to high includes it.
By their numbers in this assay, from the lowest: compound 2; then compound 1; then compounds 4 and 3 (each within the scatter of the next).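

In this assay, chloro in place of hydrogen on the carbon opposite the ring nitrogen gives a number 42 percentage points higher from compound 2 to compound 4 (beyond the scatter) as a large step. Together with a number 43.9 percentage points higher from compound 2 to compound 3 (beyond the scatter) for bromo, this shows that the large rise is not confined to one halogen at one spot of the shared core. Nothing measured here accounts for either step.

Still open, as far as these compounds go, is whether an amine or a methoxy group on this same carbon also raises the number. From the compounds shown here alone, it is also open whether chloro does so on the core of compound 1 .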